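Amide aryl swap: pyridinyl to thiazolyl in paw edema

The source may hold more compounds than are shown below. What is called first, only, known or untested is meant among the compounds shown, and "the series" means these compounds.

The series shares one core and varies the aryl group on the amide-type nitrogen. In a functional assay on the whole organism for inhibition, with Rattus norvegicus as the target, read by paw edema, at a dose of 100 mg/kg by the oral route (a lower number here means less inhibition, a higher number more inhibition at the dose given (going by the name of the read-out)), compound 1 `O=C(Nc1cccc(Cl)c1)c1c(O)c2cccnc2n(-c2ccccc2)c1=O` gives 7.6%. Compound 2 `O=C(Nc1cccc([N+](=O)[O-])c1)c1c(O)c2cccnc2n(-c2ccccc2)c1=O` gives 5.7% in this assay, and the step of a number 1.9 percentage points lower from compound 1 to compound 2 (within the scatter) is a flat one. Compound 3 `O=C(Nc1cccnc1)c1c(O)c2cccnc2n(-c2ccccc2)c1=O` gives 30.3% in this assay, the highest of the three numbers, with both steps to it beyond the scatter: a number 22.7 percentage points higher from compound 1 to compound 3 (beyond the scatter) and a number 24.6 percentage points higher from compound 2 to compound 3 (beyond the scatter).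

Compound 4 `O=C(Nc1nccs1)c1c(O)c2cccnc2n(-c2ccccc2)c1=O` has not yet been measured. It differs from compound 3 at the same position that was varied before: 1,3-thiazol-2-yl in place of pyridin-3-yl on an amide-type nitrogen. For the measured compounds named here, no measured step trades one heteroaryl for another; the two steps that bear on this place, a number 22.7 percentage points higher from compound 1 to compound 3 (beyond the scatter) and a number 24.6 percentage points higher from compound 2 to compound 3 (beyond the scatter), only show that the pyridinyl amide stands above both substituted phenyl amides by a modest margin. Whether a five-membered ring with two hetero atoms holds that margin cannot be read from the data, so the expectation is for no step beyond the scatter in this assay, with the range kept wide. The estimate for compound 4 in this assay is 26%, between 8% and 46%, which is an expected step of a number 4.3 percentage points lower from compound 3 to compound 4 (within the scatter).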

Compound 4, a percentage reported as inhibition, in the whole organism at one dose (the size of the read-out at that dose, not a potency): 4.6%
For compound 4 the middle estimate is 21.4 percentage points above the measured one; the whole stated range lies above it.
By their numbers in this assay, from the lowest: compounds 4, 2 and 1 (each within the scatter of the next); then compound 3.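

The pyridinyl margin does not carry over to the thiazolyl amide in this assay: the change is a number 25.7 percentage points lower from compound 3 to compound 4 (beyond the scatter) and is about as large as the steps that first set the pyridinyl amide apart. Compound 4 also sits level with both substituted phenyl amides, with a number 1.1 percentage points lower from compound 2 to compound 4 (within the scatter) and a number 3 percentage points lower from compound 1 to compound 4 (within the scatter), so a ring hetero atom on the amide-type nitrogen does not by itself go with the higher number, and among these four compounds only compound 3 stands apart. No measurement at hand offers a reason for the loss on going from the six-membered pyridin-3-yl ring to the five-membered 1,3-thiazol-2-yl ring.

Going by these compounds, it remains open whether the higher number belongs to pyridin-3-yl alone or extends to other rings on the same nitrogen, such as unsubstituted phenyl, pyrimidinyl or oxazolyl. The compounds shown also leave open how an aliphatic group such as a longer alkyl chain or a morpholinoethyl chain would behave at this place, and whether any of these changes holds when the phenyl group on the shared core is replaced.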